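A few compounds are considered here, and "the series" means these few. Any claim that something is new, unique, unknown or untested is made for them only; others in the source may bear on it.

Two compounds of this series have numbers in an assay on urine for inhibition of Myeloperoxidase (Homo sapiens); a higher number here means a weaker inhibitor, a lower number a stronger inhibitor. Compound 1 `NCc1c[nH]c2ccc(F)cc12` gives 900 nM, and compound 2 `Fc1ccc2[nH]cc(CCCN3CCCC3)c2c1` gives 320 nM, the lowest of the two, with compound 1 nearest at a gap beyond the scatter. Compound 3 `NCCCCc1c[nH]c2ccc(F)cc12` differs from compound 2 in one place: aminomethyl in place of pyrrolidin-1-yl on a saturated chain carbon, three bonds along the chain from an aromatic carbon. Compound 1, which also carries aminomethyl, gives 900 nM, the higher number. On that basis the step is expected to move the number up modestly, near the edge of the scatter, about a 1.9-fold higher number from compound 2 to compound 3 (0.27 log units; within the scatter). Compound 3 is estimated at 600 nM, with a range from 250 nM to 1500 nM.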

Compound 3, half-maximal inhibitory concentration: 15 nM
The estimate for compound 3 lay 40-fold (1.60 log units) above the measured number, and the stated range ends above it.
By their numbers in this assay, from the lowest: compound 3; then compound 2; then compound 1.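

In this assay the group at the end of this chain proves a strong lever: aminomethyl in place of pyrrolidin-1-yl on the saturated chain carbon gives a 21-fold lower number from compound 2 to compound 3 (1.33 log units; beyond the scatter), and 3-aminopropyl in place of amino gives a 60-fold lower number from compound 1 to compound 3 (1.78 log units; beyond the scatter). The unsubstituted amino end alone does not bring the low number, since compound 1 also carries it, on its shorter chain. Nothing shown here explains the size of either step. Open, as far as these compounds go, is whether a longer chain, or a methylamino or dimethylamino end group on the chain of compound 3, keeps the low number.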